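Urea substituent variation and tolerated concentration

A few compounds are considered here, and "the series" means these few. Any claim that something is new, unique, unknown or untested is made for them only; others in the source may bear on it.

Measured so far:
compound 1 `CCN(CC)C(=O)NCCCC(C)Nc1cc(OC)cc2cccnc12` — in an ADME assay on HEL cells (Homo sapiens) for cytotoxicity (a lower number here means that less compound is tolerated, a higher number that more compound is tolerated), a limit only: > 100000 nM
compound 2 `COc1cc(NC(C)CCCNC(=O)NCc2ccccc2)c2ncccc2c1` — in this assay gives 66000 nM
compound 3 `COc1cc(NC(C)CCCNC(=O)N(C2CCCCC2)C2CCCCC2)c2ncccc2c1` — in this assay gives 27000 nM

Compound 1 stands at the top of the numbers shown: its entry in this assay is a limit of the assay and not a number (the limit of > 100000 nM in this assay, at which 1 of the 3 values shown sits). Compound 2 and compound 3 both return numbers, compound 3 the lower of the two.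

Compound 4 `COc1cc(NC(C)CCCNC(=O)NC2CCCC2)c2ncccc2c1` has not been measured in this assay. It differs from compound 1 by cyclopentylamino in place of diethylamino on a carbonyl carbon. Among the measured compounds shown here, the one measured step that bears on this change is an at least 1.5-fold lower number from compound 1 to compound 2 (0.18 log units; that floor lies within the scatter), a secondary urea replacing the diethylamino on the same carbonyl carbon; its floor lies within the scatter. For the measured compounds named here, compound 3 shows that a bulkier saturated substitution at the urea gives a clearly lower number, but no step to compound 3 is defined here.

For compound 4 a modest lowering is expected, an at least 1.3-fold lower number from compound 1 to compound 4 (0.12 log units; that floor lies within the scatter), much of it within the scatter. Compound 4 is estimated at 75000 nM, between 30000 nM and 150000 nM.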

Compound 4, half-maximal cytotoxic concentration: 56000 nM
For compound 4 the middle estimate is 1.3-fold (0.13 log units) above the measured one; measured number inside the range.
By their numbers in this assay, from the lowest: compound 3; then compounds 4 and 2 (each within the scatter of the next). At a limit, above all of these: compound 1.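

In this assay, cyclopentyl in place of benzyl on an amide-type nitrogen gives a 1.2-fold lower number from compound 2 to compound 4 (0.07 log units; within the scatter), so these two groups cannot be told apart here. The other step is an at least 1.7-fold lower number from compound 1 to compound 4 (0.25 log units; that floor lies within the scatter), a second floor that sits alongside an at least 1.5-fold lower number from compound 1 to compound 2 (0.18 log units; that floor lies within the scatter). Both steps remain floors and their true size stays unknown, since compound 1 stands at a limit of the assay and not at a number: the limit of > 100000 nM in this assay, at which 1 of the 4 values shown sits.

Open, going by these compounds, is whether a single cyclohexyl or a plain methyl on this nitrogen would give a number beyond the scatter of compound 2 and compound 4. Equally open, on these data alone, is whether an amine or a carboxylic acid carried on the cyclopentyl group would shift the tolerated concentration at all.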